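This account rests on a few compounds, and the source may have more. Where it says the series, first, only, none or still open, it means among the compounds named here.

In a functional assay on M21 cells (Homo sapiens) for antiproliferative activity, read by sulforhodamine B assay, with a stated time of 48 h (on this read-out higher numbers stand for weaker inhibition and lower numbers for stronger inhibition), two compounds built on the same core have been measured so far. Compound 1 `CCCCOc1ccc(NS(=O)(=O)c2ccc(N3CCNC3=O)cc2)cc1`, which carries a butoxy group, gives 580 nM. Compound 2 `O=C1NCCN1c1ccc(S(=O)(=O)Nc2ccc(Br)cc2)cc1`, which carries a bromo group instead, gives 130 nM, the lower of the two numbers and so the stronger inhibition.

The next compound, compound 3 `COc1ccc(NS(=O)(=O)c2ccc(N3CCNC3=O)cc2)cc1`, has not yet been measured. It differs from compound 2 by a single change: methoxy in place of bromo on an aromatic carbon. Methoxy stands in place of bromo on an aromatic carbon, para to a large group.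

Among the compounds with values here, only one measured step bears on this change: a 4.5-fold lower number from compound 1 to compound 2 (0.65 log units; beyond the scatter). That step is modest but beyond the scatter, and it exchanges bromo and butoxy at the same place. Methoxy is a shorter chain than butoxy, so compound 3 may land between the two measured compounds, although one step is thin evidence. The estimated step is a 2.3-fold higher number from compound 2 to compound 3 (0.36 log units; beyond the scatter), which is expected to be no larger than the measured one. Compound 3 is expected to give about 300 nM, with an estimated range from 110 nM to 700 nM.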

Compound 3, half-maximal inhibitory concentration: 580 nM
The estimate for compound 3 lay 1.9-fold (0.29 log units) below the measured number; the range from low to high includes it.
By their numbers in this assay, from the lowest: compound 2; then compounds 1 and 3 (each within the scatter of the next).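

In this assay, methoxy in place of bromo on this aromatic carbon, para to a large group, gives a 4.5-fold higher number from compound 2 to compound 3 (0.65 log units; beyond the scatter). Shortening the chain on the oxygen from butoxy to methoxy gives no change at the digits printed from compound 1 to compound 3 (within the scatter), so the two chains cannot be told apart here, something a single chain could not reveal, and the expectation of a middle position for a shorter chain finds no support in these compounds. Among the three compounds, bromo stands apart from both groups attached through oxygen, while the length of that chain makes no difference beyond the scatter, and nothing measured here accounts for this difference between bromo and the two chains.

Going by these compounds, with only one halogen and two chains in view, it remains open whether chloro, an amine or a carboxylic acid at this place would give numbers nearer to compound 2 or to compound 3. On these data alone, it is also open whether a longer chain such as hexyloxy would still match compound 1 and compound 3, or whether the flat response ends somewhere beyond butoxy.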